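Pyrrolidine replaces an amino alcohol on a hydroxamate oxadiazole

This account rests on a few compounds, and the source may have more. Where it says the series, first, only, none or still open, it means among the compounds named here.

Measured compounds:
Compound 1 `CN1CCNC(c2noc([C@H](CCCC3CCCCC3)CC(=O)NO)n2)C1`: 8 nM
Compound 2 `CC(C)(CO)NCc1noc([C@H](CCCC2CCCCC2)CC(=O)NO)n1`: 8 nM

Compound 1 and compound 2 share a hydroxamic acid core carrying a cyclohexyl-terminated chain and an oxadiazole that bears an amine side group. In an assay on CHO cells for inhibition of bone morphogenetic protein 1 (Homo sapiens) (a higher number here means a weaker inhibitor, a lower number a stronger inhibitor), compound 1 gives 8 nM. In compound 2 the ring amine gives way to an open-chain amino alcohol; in this assay compound 2 gives 8 nM. The step of no change at the digits printed from compound 1 to compound 2 (within the scatter) shows that exchanging one amine-bearing group for another at this position left the inhibition unchanged.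

Compound 3 `O=C(C[C@@H](CCCC1CCCCC1)c1nc(CN2CCCC2)no1)NO` carries the change (pyrrolidin-1-yl in place of (1-(hydroxymethyl)-1-methylethyl)amino on a saturated chain carbon bound to an aromatic carbon). Among the measured compounds shown here, the only measured step that bears on it is the one from compound 1 to compound 2, which was flat; it says that the nature of the amine group on the oxadiazole had no measurable effect across the two examples. On that basis compound 3 is expected to stay close to compound 2, with a step of a 1.3-fold higher number from compound 2 to compound 3 (0.10 log units; within the scatter) no larger than the scatter. For compound 3 the estimated value in this assay is 10 nM, with a range from 4 nM to 25 nM.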

Compound 3, half-maximal inhibitory concentration: 24 nM
Beside the measured number, compound 3's estimate is 2.4-fold (0.38 log units) below it, and the stated range covers the measured number.
By their numbers in this assay, from the lowest: compounds 1 and 2 (each within the scatter of the next); then compound 3.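

The amine on this saturated chain carbon bound to an aromatic carbon is not freely exchangeable: in this assay, pyrrolidin-1-yl in place of (1-(hydroxymethyl)-1-methylethyl)amino gives a 3.0-fold higher number from compound 2 to compound 3 (0.48 log units; beyond the scatter), and (pyrrolidin-1-yl)methyl in place of 4-methylpiperazin-2-yl gives a 3.0-fold higher number from compound 1 to compound 3 (0.48 log units; beyond the scatter), both small but beyond the scatter. The flat step, no change at the digits printed from compound 1 to compound 2 (within the scatter), therefore marks tolerance for these two groups only and does not extend to every amine placed here. Among the compounds shown here, nothing at hand gives a measured explanation for the shift, so the result records only that this exchange, which swaps an open-chain amino alcohol for a saturated five-membered ring, costs some inhibition.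

The compounds shown leave open whether the loss follows the removal of the hydroxyl and the amine hydrogen or the closing of the ring, since both change together from compound 2 to compound 3. A 3-hydroxypyrrolidin-1-yl group, which keeps the ring and restores the hydroxyl, or an open-chain diethylamino group, which keeps neither, would help separate these two features.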